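The source may hold more compounds than are shown below. What is called first, only, known or untested is meant among the compounds shown, and "the series" means these compounds.

Measured compounds:
- compound 1 `COC(=O)CN(C)c1nc(Nc2ccc(Cl)cc2)ncc1[N+](=O)[O-]`: 23500 nM
- compound 2 `CCOC(=O)CNc1nc(Nc2ccc(Cl)cc2)ncc1[N+](=O)[O-]`: > 100000 nM

In a functional assay on A549 cells (Homo sapiens) for antiproliferative activity, read by MTT assay, with a stated time of 48 h (on this read-out higher numbers stand for weaker inhibition and lower numbers for stronger inhibition), compound 1 gives 23500 nM. For compound 2 this assay reports only a limit, > 100000 nM, so its true number is not known; it sits at the limit of > 100000 nM in this assay, at which 1 of the 2 values shown sits. Going by the values given here, the single measured step, an at least 4.2-fold higher number from compound 1 to compound 2 (0.62 log units; beyond the scatter), concerns the amino side chain, not the aryl ring.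

Compound 3 `CCOC(=O)CNc1nc(Nc2cccc(OC)c2)ncc1[N+](=O)[O-]` differs from compound 2 in the ring carried by the amino nitrogen: 3-methoxyphenyl in place of 4-chlorophenyl on a nitrogen on an aromatic ring. Among the compounds with values here, no measured pair shows the effect of exchanging the 4-chlorophenyl for a 3-methoxyphenyl, so there is no basis for expecting a step in either direction beyond the scatter. Compound 2 starts at the limit, so compound 3 is expected to stay near it, with a wide range: a step of about a number no higher from compound 2 to compound 3 (the limit leaves the size open) is estimated, giving an expected value of 100000 nM for compound 3, between 25000 nM and 400000 nM.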

Compound 3, half-maximal inhibitory concentration: 36100 nM
Beside the measured number, compound 3's estimate is 2.8-fold (0.44 log units) above it; measured number inside the range.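

The ring carried by the amino nitrogen matters as well as the amino side chain: in this assay there is an at least 2.7-fold lower number from compound 2 to compound 3 (0.44 log units; beyond the scatter), with 3-methoxyphenyl in place of 4-chlorophenyl. Going by these compounds alone, until now, only a change in the side chain had been seen to shift the number, so this is the first sign that the aryl position can also move it. The true size of this step stays open, since the value for compound 2 is only a limit: the limit of > 100000 nM in this assay, at which 1 of the 3 values shown sits.

With only these two rings, the loss of the chlorine cannot be separated from the gain of the methoxy group, and an unsubstituted phenyl ring would help to tell them apart. As far as these compounds go, it also remains open whether the same exchange would act alike with the side chain of compound 1.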